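Isobutyl for 3-methylphenyl: a Cytotoxicity Estimate

The compounds below may be only part of what the source reports. "The series", "measured", "known", "first", "only" and "open" are said of these compounds alone.

Compound 1, `Cc1cccc(Cn2ccc3nc(-c4ccccc4)nc-3c2)c1`, in an ADME assay on MDBK cells (Bos taurus) for cytotoxicity; on this read-out higher numbers stand for lower toxicity in this test and lower numbers for higher toxicity in this test: > 100000 nM, a limit of the assay.
Compound 2, `Fc1ccccc1Cn1ccc2nc(-c3ccccc3)nc-2c1`: > 100000 nM, a limit.
Compound 3, `CCn1ccc2nc(-c3ccccc3)nc-2c1`: > 100000 nM, a limit.

Compound 1 stands only at a limit, and so do the two others. The step to compound 4, `CC(C)CCn1ccc2nc(-c3ccccc3)nc-2c1`, is isobutyl in place of 3-methylphenyl on a saturated chain carbon bound to an aromatic nitrogen. The steps a step that the two limits leave unreadable from compound 1 to compound 2 and a step that the two limits leave unreadable from compound 1 to compound 3 touch the same place, but their sizes cannot be read because of the limit of > 100000 nM in this assay, at which 3 of the 3 values shown sit. Among the measured compounds shown here, no measured step therefore gives a readable size, and for compound 4 no step beyond the scatter in this assay is expected in either direction. The estimate for compound 4 is 100000 nM, between 40000 nM and 250000 nM, which is expected to amount to a number no higher from compound 1 to compound 4 (the limit leaves the size open).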

Compound 4, half-maximal cytotoxic concentration: > 100000 nM
Compound 4 ended at the assay's limit; the forecaster's own chance of this, stated with the estimate: 80%; the middle value sits exactly at the limit.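

Compound 4 joins compounds 1, 2 and 3, and none of the steps among them can be read, because all four values are limits: the limit of > 100000 nM in this assay, at which 4 of the 4 values shown sit.

The compounds shown leave open whether these groups differ at all in cytotoxicity.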